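Removing the nitrooxy group from compound 2

A few compounds are considered here, and "the series" means these few. Any claim that something is new, unique, unknown or untested is made for them only; others in the source may bear on it.

In a functional assay on CLL cells (Homo sapiens) for cytotoxicity, read by MTT assay, with a stated time of 48 h (on this read-out lower numbers stand for an effect already at smaller amounts and higher numbers for an effect only at larger amounts of compound), compound 1 (`C=C(CC)C(=O)c1ccc(OCC(=O)NCC(=O)O)c(Cl)c1Cl`) gives > 25000 nM as a limit of the assay and not a number. Among the measured compounds shown here, compound 2 (`C=C(CC)C(=O)c1ccc(OCC(=O)NCO[N+](=O)[O-])c(Cl)c1Cl`) gives 4100 nM as the only true number so far. Compound 3 (`C=C(CC)C(=O)c1ccc(OCC(=O)NCCO)c(Cl)c1Cl`) carries hydroxymethyl in place of nitrooxy on a saturated chain carbon bound to an amide-type nitrogen. For the measured compounds named here, the one measured step bearing on this change is an at least 6.0-fold lower number from compound 1 to compound 2 (0.78 log units; beyond the scatter) with nitrooxy replacing carboxy at that same place. Hydroxymethyl is untested there, so this step suggests a direction but fixes no size. A higher number is expected in this assay once nitrooxy leaves, and a step of a 2.9-fold higher number from compound 2 to compound 3 (0.47 log units; beyond the scatter) is estimated here. The estimate for compound 3 is 12000 nM with an expected range of 5000 nM to 25000 nM in this series.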

Compound 3, half-maximal effective concentration: > 25000 nM
Compound 3 ended at the assay's limit (the forecaster's own chance of this, stated with the estimate: 30%); middle value at least 2.0-fold (0.31 log units) from the limit.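

In this assay compound 3 gives > 25000 nM, a limit of the assay and not a number. Hydroxymethyl in place of nitrooxy, on a saturated chain carbon bound to an amide-type nitrogen, gives an at least 6.0-fold higher number from compound 2 to compound 3 (0.78 log units; beyond the scatter), so the loss seen earlier with carboxy now also appears with a second, uncharged group. Of the groups compared at this place, only nitrooxy gives a true number, which so far rests on compound 2 alone.

On these data alone, the comparison of compound 1 with compound 3 cannot be read, and the two groups cannot be ranked against each other: the limit of > 25000 nM in this assay, at which 2 of the 3 values shown sit. Whether the effect depends on nitrooxy itself stays open, as does the outcome with an amine, a methyl ether or nitrooxy on a longer chain at this place.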